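The source may hold more compounds than are shown below. What is called first, only, known or untested is meant among the compounds shown, and "the series" means these compounds.

Of the compounds shown here, three sharing one core have been tested in a functional assay on MGC-803 cells (Homo sapiens) for antiproliferative activity, read by CCK-8 assay, with a stated time of 72 h, tested at 8 uM; on this read-out higher numbers stand for a stronger effect at the one concentration tested and lower numbers for a weaker effect. Compound 1 `Nc1ccccc1NC(=O)c1ccc(CSC(=S)N2CCc3ccccc32)cc1` gives 87%. Compound 2 `Nc1ccccc1NC(=O)c1ccc(CSC(=S)N2CCc3cc(Cl)ccc32)cc1` gives 82.2%, and compound 3 `CC1CCN(C(=S)SCc2ccc(C(=O)Nc3ccccc3N)cc2)CC1` gives 81.9%. Compound 3 has the lowest of the three numbers, yet its gaps to the others are small: the step of a number 5.1 percentage points lower from compound 1 to compound 3 (within the scatter) and the step of a number 0.3 percentage points lower from compound 2 to compound 3 (within the scatter) both lie within the scatter, so no order among the three can be claimed.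

Compound 4 `CN1CCN(C(=S)SCc2ccc(C(=O)Nc3ccccc3N)cc2)CC1` has not yet been measured in this assay. It differs from compound 3 in one place: 4-methylpiperazin-1-yl in place of 4-methylpiperidin-1-yl on a thiocarbonyl carbon. For the measured compounds named here, the steps that bear on this change are the two earlier replacements on that same thiocarbonyl carbon, both of which stayed within the scatter; a ring of similar size is exchanged for another here, so a step beyond the scatter is not expected. The expected step of a number 1.9 percentage points lower from compound 3 to compound 4 (within the scatter) is estimated to be small. Compound 4 is therefore expected to give about 80%, with a range from 66% to 92%.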

Compound 4, a percentage reported as inhibition, at one concentration (the size of the read-out at that concentration, not a potency): 84.4%
Compound 4: middle estimate off by 4.4 percentage points, on the low side, and the stated range covers the measured number.
By their numbers in this assay, from the lowest: compounds 3, 2, 4 and 1 (each within the scatter of the next).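

In this assay, the exchange on the thiocarbonyl carbon adds a second ring nitrogen and, by the count, one hydrogen-bond acceptor, and it gives a number 2.5 percentage points higher from compound 3 to compound 4 (within the scatter) and so stays within the scatter. Set against the two other groups, 4-methylpiperazin-1-yl gives a number 2.2 percentage points higher from compound 2 to compound 4 (within the scatter) and a number 2.6 percentage points lower from compound 1 to compound 4 (within the scatter), so all four groups at this position now read alike at this one concentration, and the group with two ring hetero atoms is among them. Nothing measured here explains this result.

Still open, on these data alone, is whether this position accepts a group of another kind, such as an open-chain diethylamino group or a piperidine ring carrying a carboxylic acid. With only one concentration, any differences in potency among these four compounds also remain unseen.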